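A Ring for an Isopropyl: Expected Stability of Compound 3

The compounds below may be only part of what the source reports. "The series", "measured", "known", "first", "only" and "open" are said of these compounds alone.

compound 1, `COc1cc(-c2cnn3cc(OC)c(C(C)C)nc23)ccn1`: 14%
compound 2, `COc1cn2ncc(-c3ccnc(OC(C)(C)C)c3)c2nc1-c1cnn(C)c1`: 61%

Of the compounds shown here, two have been measured in an ADME assay on microsomes from liver (Rattus norvegicus) for metabolic stability, with a stated time of 60 min, tested at 1 uM; on this read-out lower numbers stand for a less stable compound and higher numbers for a more stable compound. Compound 1 `COc1cc(-c2cnn3cc(OC)c(C(C)C)nc23)ccn1` gives 14%, the lowest of the two numbers, while compound 2 `COc1cn2ncc(-c3ccnc(OC(C)(C)C)c3)c2nc1-c1cnn(C)c1`, the nearest, gives 61%, a number higher by more than the usual scatter. Compound 3 `COc1cc(-c2cnn3cc(OC)c([C@H]4COC(C)(C)C4)nc23)ccn1` has not been measured. It differs from compound 1 in one place: a group of 7 heavy atoms (6 carbon, 1 oxygen; one five-membered non-aromatic ring with 1 hetero atom) in place of a group of 3 heavy atoms (3 carbon; no ring), on an aromatic carbon. The isopropyl leaves and a group with one five-membered non-aromatic ring with 1 hetero atom and 1 defined stereocentre enters on an aromatic carbon of the shared core. Going by the values given here, no step between two measured compounds shows the effect of such a change, so the expectation rests on compound 1 alone. Because compound 1 gives 14%, there is little room for a fall. The step of a number 16 percentage points higher from compound 1 to compound 3 (beyond the scatter) is expected to be upward and modest, perhaps just beyond the scatter. Compound 3 is estimated at 30%, within a range from 10% to 60%.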

Compound 3, percent of the compound remaining: 30%
Compound 3: middle estimate and measured number agree at the digits printed, and the stated range covers the measured number.
By their numbers in this assay, from the lowest: compound 1; then compound 3; then compound 2.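

In this assay, putting the group with one five-membered non-aromatic ring with 1 hetero atom in place of the isopropyl gives a number 16 percentage points higher from compound 1 to compound 3 (beyond the scatter), the first single-place change shown on this aromatic carbon of the shared core. The position therefore takes a group of 7 heavy atoms with a ring, 1 hydrogen-bond acceptor and 1 defined stereocentre, and the read-out moves upward beyond the usual scatter. Nothing shown bears on the reason for this rise.

The compounds shown leave open whether the ring, its oxygen, its methyl groups or its stereocentre carries the step, and whether the mirror-image form would read the same. They also leave open how an amine or a plain cyclopentyl on this aromatic carbon would read in this assay.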